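The source may hold more compounds than are shown below. What is called first, only, known or untested is meant among the compounds shown, and "the series" means these compounds.

In an in vitro functional assay on HEK285-7 cells for antagonist activity at prostaglandin D2 receptor 2 (Homo sapiens), read by BRET and beta-arrestin recruitment (on this read-out lower numbers stand for stronger inhibition and higher numbers for weaker inhibition), compound 1 `Nc1nc(-c2ccc(Cl)cc2)c(CC(=O)O)s1` gives only a limit, > 100000 nM, and not a number. Compound 2 `COc1ccc(C(c2ccccc2)c2nc(-c3ccc(Cl)cc3)c(CC(=O)O)s2)cc1` gives 76 nM in this assay. Compound 3 `N#Cc1cc(-c2nc(C(c3ccc(F)cc3)c3ccc(F)cc3)sc2CC(=O)O)ccc1F` gives 520 nM, the highest of the two numbers seen, and its gap to compound 2 lies beyond the usual scatter of repeated measurements. Compound 4 `O=C(O)Cc1sc(C(c2ccc(F)cc2)c2ccc(F)cc2)nc1-c1ccnc(O)c1` differs from compound 3 in a single place: 2-hydroxypyridin-4-yl in place of 3-cyano-4-fluorophenyl on an aromatic carbon. Going by the values given here, no measured pair of compounds shows an exchange of this kind, so no step of this sort is known here. A small step toward a higher number, that is toward weaker inhibition, is expected, a 1.9-fold higher number from compound 3 to compound 4 (0.28 log units; within the scatter). Compound 4 is therefore estimated at 1000 nM, with a range from 250 nM to 4000 nM.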

Compound 4, half-maximal inhibitory concentration: 890 nM
Compound 4: middle estimate off by 1.1-fold (0.05 log units), on the high side, within the range that was stated.
By their numbers in this assay, from the lowest: compound 2; then compounds 3 and 4 (each within the scatter of the next). At a limit, above all of these: compound 1.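

The exchange gives a 1.7-fold higher number from compound 3 to compound 4 (0.23 log units; within the scatter). Going by these compounds alone, this is the first measured change on this aromatic carbon, and it shows that a ring of carbon only, bearing a nitrile and a fluorine, and a ring with a hetero atom, bearing a hydroxyl group, read alike here. Nothing shown accounts for this match.

As far as these compounds go, because the whole group changes at once, the part played by the nitrile, the fluorine, the ring nitrogen or the hydroxyl group stays open. So does the outcome with a plain phenyl or an amine at this position.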